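The source may hold more compounds than are shown below. What is called first, only, known or untested is meant among the compounds shown, and "the series" means these compounds.

Measured so far:
compound 1, `COc1ccc(F)cc1CNCCCNc1ccnc2cc(Cc3ccc(C#N)cc3)ccc12`, in an ADME assay for permeability, using PAMPA, with a stated time of 30 min, at pH 7.4; on this read-out higher numbers stand for higher permeability and lower numbers for lower permeability: 23 10^-6 cm/s
compound 2, `FC(F)(F)c1ccc(-c2ccc3c(NCCCNCc4ccco4)ccnc3c2)cc1`, in this assay: 237 10^-6 cm/s
compound 3, `COc1cccc(CNCCCNc2ccnc3cc(Cc4cccc(C(F)(F)F)c4)ccc23)c1O`, in this assay: 23 10^-6 cm/s

Compound 1 stands level with compound 3 at the digits printed, and together these two give the lowest of the three numbers in this assay. Compound 2 is the furthest from compound 1, with a number beyond the scatter of the method; the other two compounds are within the scatter of each other, so no order between them is claimed.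

The unmeasured compound 4, `COc1ccc(F)cc1CNCCCNc1ccnc2cc(Oc3ccc(C(C)(C)C)cc3)ccc12`, differs from compound 1 in one place: 4-(tert-butyl)phenoxy in place of 4-cyanobenzyl on an aromatic carbon. No step between two measured compounds matches this change, so nothing directly shown tells its size. The one substantial spread among the three measured compounds, from compound 1 to compound 2, shows that numbers well beyond the scatter of each other are reachable within this set; compound 4 sits structurally closer to compound 1 than compound 2 does. An upward step beyond the scatter, though smaller than the gap between compound 1 and compound 2, is expected here, namely a 2.6-fold higher number from compound 1 to compound 4 (0.42 log units; beyond the scatter). For compound 4 in this assay the estimated value is 60 10^-6 cm/s, expected to lie between 20 10^-6 cm/s and 180 10^-6 cm/s.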

Compound 4, apparent permeability: 317 10^-6 cm/s
The estimate for compound 4 lay 5.3-fold (0.72 log units) below the measured number; the measured number lies above the stated range.
By their numbers in this assay, from the lowest: compounds 1 and 3 (each within the scatter of the next); then compounds 2 and 4 (each within the scatter of the next).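

In this assay, putting 4-(tert-butyl)phenoxy in place of 4-cyanobenzyl on this aromatic carbon gives a 14-fold higher number from compound 1 to compound 4 (1.14 log units; beyond the scatter), a large step that lies beyond the scatter. Within the data shown here, this is the first step in the set that can be tied to one place: the earlier compounds differed from each other in more than one place, so their spread could not be assigned to any single position, whereas here everything else in compound 1 stays the same and this position alone accounts for the change. Nothing at hand says what lies behind the size of this step.

The change replaces the link to the core and the group at the far end of the ring in one move, so the step cannot be divided between them until a 4-cyanophenoxy or a 4-(tert-butyl)benzyl group is seen at the same carbon. Also open, on these data alone, are how a carboxylic acid or an amine on that ring would read, and whether the same exchange gives a step of similar size on a compound other than compound 1.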